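Substituting the Aromatic Oxygen of Compound 1

The compounds below may be only part of what the source reports. "The series", "measured", "known", "first", "only" and "open" are said of these compounds alone.

Measured in a functional assay on NCI-H460 cells (Homo sapiens) for antiproliferative activity; a lower number here means a stronger inhibitor, a higher number a weaker inhibitor:
Compound 1 `COc1cc(/C=C\Cc2cc(O)c3ccsc3c2)cc(OC)c1OC`: 74 nM
Compound 2 `COc1cc(/C=C\Cc2cc(O)c3ccoc3c2)cc(OC)c1OC`: 53 nM

Compound 1 stands level with compound 2, the two values lying within the scatter of each other. Compound 3 `COc1cc(/C=C\Cc2cc(OP(=O)(O)O)c3ccsc3c2)cc(OC)c1OC` keeps the core of compound 1 and differs in one place: a group of 4 heavy atoms (3 oxygen, 1 phosphorus; no ring) in place of a hydrogen atom, on an oxygen on an aromatic ring. Within the data shown here, no measured pair shows this change, so the expectation rests on compound 1 alone, at 74 nM. A modest move towards a weaker inhibitor is expected, the estimated step being a 1.6-fold higher number from compound 1 to compound 3 (0.21 log units; within the scatter). In this assay the estimated value for compound 3 is 120 nM, with an expected range of 40 nM to 500 nM.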

Compound 3, half-maximal inhibitory concentration: 620 nM
Beside the measured number, compound 3's estimate is 5.2-fold (0.71 log units) below it, and the stated range ends below it.
By their numbers in this assay, from the lowest: compounds 2 and 1 (each within the scatter of the next); then compound 3.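

In this assay the group of 4 heavy atoms in place of the hydrogen on this oxygen gives an 8.4-fold higher number from compound 1 to compound 3 (0.92 log units; beyond the scatter) and so moves the series towards a weaker inhibitor. Among these compounds, compound 1 and compound 2 both keep that hydrogen, so this is the first sign that the oxygen on the aromatic ring responds to substitution. Nothing available explains the loss.

Open, going by these compounds, is whether a smaller group on this oxygen, such as a methyl or an acetyl, would cost as much, and whether the same change on compound 2 would behave alike.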